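The source may hold more compounds than are shown below. What is called first, only, known or untested is meant among the compounds shown, and "the series" means these compounds.

Among the compounds with values here, compound 2 `COc1ccc(-c2cc(-c3ccc(S(=O)(=O)NC4CC4)cc3)cnc2N)cn1` stands highest of the two numbers so far: in a physicochemical assay for lipophilicity, at pH 7.4 (a higher number here means a more lipophilic compound, a lower number a more polar compound), compound 2 gives 2.7, and compound 1 `COc1ccc(-c2cc(-c3cccc(S(C)(=O)=O)c3)cnc2N)cn1` gives 2.3, a gap beyond the scatter. Compound 3 `COc1ccc(-c2cc(-c3ccc(C(N)=O)cc3)cnc2N)cn1` remains to be measured. It differs from compound 2 by carbamoyl in place of cyclopropylsulfamoyl on an aromatic carbon. Within the data shown here, no measured pair isolates this change, so the expectation rests on the structural change alone. The step of a number 0.90 log units lower from compound 2 to compound 3 (beyond the scatter) is expected to be a drop beyond the scatter. Compound 3 is accordingly estimated at 1.8 in this assay, within a range from 1.3 to 2.3.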

Compound 3, distribution coefficient: 1.7
Estimate against measurement, compound 3: 0.10 log units above; measured number inside the range.
By their numbers in this assay, from the lowest: compound 3; then compound 1; then compound 2.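

In this assay, within the data shown here, the step of a number 1.00 log units lower from compound 2 to compound 3 (beyond the scatter) is the first reading of a single change at this place, on an aromatic carbon para to a large group, which the earlier compounds did not offer. The change takes away the sulfur and the three-membered ring together, so the step cannot be divided between them. Nothing measured here accounts for its size. Open, going by these compounds, is where an unsubstituted sulfamoyl would fall relative to compound 2 and compound 3. Also open, on these data alone, is how an amine or a carboxylic acid at this place would read in this assay.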